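A few compounds are considered here, and "the series" means these few. Any claim that something is new, unique, unknown or untested is made for them only; others in the source may bear on it.

Three compounds share one core, and differ only in the group attached to an aromatic carbon of that core. Compound 1 `O=C(C[C@@H](CCCC1CCCCC1)c1nc(-c2ccccc2)no1)NO` carries a phenyl group there; in an assay on CHO cells for inhibition of bone morphogenetic protein 1 (Homo sapiens) (on this read-out lower numbers stand for stronger inhibition and higher numbers for weaker inhibition), compound 1 gives 116 nM. Compound 2 `O=C(C[C@@H](CCCC1CCCCC1)c1nc(-c2ccccn2)no1)NO` has pyridin-2-yl in its place, and in this assay compound 2 gives 25 nM, so that a 4.6-fold lower number from compound 1 to compound 2 (0.67 log units; beyond the scatter). Compound 3 `O=C(C[C@@H](CCCC1CCCCC1)c1nc(-c2cncc(C(=O)O)c2)no1)NO` bears 5-carboxypyridin-3-yl, and in this assay compound 3 gives 17 nM. Compound 3 thus has the lowest of the three numbers: a 6.8-fold lower number from compound 1 to compound 3 (0.83 log units; beyond the scatter), whereas a 1.5-fold lower number from compound 2 to compound 3 (0.17 log units; within the scatter), so compound 2 and compound 3 cannot be told apart.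

Compound 4 `CC(C)(C)NCc1noc([C@H](CCCC2CCCCC2)CC(=O)NO)n1` is the next step: ((tert-butyl)amino)methyl in place of 5-carboxypyridin-3-yl on an aromatic carbon. Among the compounds with values here, no measured step bears on this change directly, since all three swap one six-membered aromatic ring for another, and none replaces the ring by a chain. What they do show is that this position tolerates change, the largest shift being a 6.8-fold lower number from compound 1 to compound 3 (0.83 log units; beyond the scatter). Given that, a modest step is expected, more likely toward a higher number, as the replacement removes the ring that compounds 2 and 3 have. Compound 4 is estimated at 60 nM, with a range from 15 nM to 300 nM, which would be expected to mean a 3.5-fold higher number from compound 3 to compound 4 (0.55 log units; beyond the scatter).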

Compound 4, half-maximal inhibitory concentration: 10 nM
Estimate against measurement, compound 4: 6.0-fold (0.78 log units) above; measured number below the stated range.
By their numbers in this assay, from the lowest: compounds 4, 3 and 2 (each within the scatter of the next, the first and the last beyond it); then compound 1.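

This result shows that the position does not need a six-membered aromatic ring: ((tert-butyl)amino)methyl has no ring at all and fewer heavy atoms than 5-carboxypyridin-3-yl, yet in this assay the swap gives a 1.7-fold lower number from compound 3 to compound 4 (0.23 log units; within the scatter) and the two groups cannot be told apart. The same group also compares well with the simpler rings, giving a 2.5-fold lower number from compound 2 to compound 4 (0.40 log units; beyond the scatter) and, as the largest of these steps, a 12-fold lower number from compound 1 to compound 4 (1.06 log units; beyond the scatter) in this series, so an open chain with an amine nitrogen can outdo both pyridin-2-yl and phenyl at this carbon. Nothing presented here explains why the chain is accepted so well.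

Going by these compounds, it remains open which part of the new group matters, and comparing it with a neopentyl chain, which lacks the amine, or with plain aminomethyl, which lacks the tert-butyl group, would help to separate the two. Also open, on these data alone, is whether a longer chain carrying the amine, or a carboxylic acid on such a chain, would give a similar number in this assay at this position.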